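The source may hold more compounds than are shown below. What is called first, only, known or untested is meant among the compounds shown, and "the series" means these compounds.

Compound 3 `CCCCC[Se]c1nc(NCc2ccccc2)c2ccccc2n1` gives the highest number of the three measured compounds in a functional assay on HT-29 cells (Homo sapiens) for cytotoxicity, read by MTT assay, with a stated time of 72 h (on this read-out higher numbers stand for weaker inhibition of growth and lower numbers for stronger inhibition of growth), with 72700 nM. Compound 1 `C[Se]c1nc(N)c2ccccc2n1` gives 27600 nM in this assay, and compound 2 `Sc1nc(NCc2ccccc2)c2ccccc2n1` gives 10100 nM. Compound 4 `CCCCC[Se]c1nc(N)c2ccccc2n1` differs from compound 3 by hydrogen in place of benzyl on a nitrogen on an aromatic ring. Going by the values given here, no measured step reproduces this change alone: the only single-place step, a 7.2-fold higher number from compound 2 to compound 3 (0.86 log units; beyond the scatter), concerns the group on the aromatic carbon, not the nitrogen. Compound 1 carries the same amino group as compound 4 but a shorter chain on selenium, so its value only hints at the range. An expected step of a 2.1-fold lower number from compound 3 to compound 4 (0.32 log units; beyond the scatter) for compound 4 is therefore a guess toward a lower number. Compound 4 is estimated at 35000 nM, between 12000 nM and 100000 nM.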

Compound 4, concentration for 50% growth inhibition: 40300 nM
Compound 4: middle estimate off by 1.2-fold (0.06 log units), on the low side; the measured number falls inside the stated range.
By their numbers in this assay, from the lowest: compound 2; then compounds 1, 4 and 3 (each within the scatter of the next, the first and the last beyond it).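

In this assay, going by these compounds alone, hydrogen in place of benzyl on the nitrogen gives a 1.8-fold lower number from compound 3 to compound 4 (0.26 log units; within the scatter), so this change, seen alone for the first time, stays within the scatter. Butyl in place of hydrogen on the saturated chain carbon bound to selenium gives a 1.5-fold higher number from compound 1 to compound 4 (0.16 log units; within the scatter), which also stays within the scatter, so neither change separates these compounds in this read-out. No evidence is available to explain either result. The compounds shown leave open whether a carboxylic acid in place of benzyl on that nitrogen, or a longer chain on selenium, would move the number beyond the scatter.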